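Shifting the Methyl Group: From Compound 3 to Compound 4

The source may hold more compounds than are shown below. What is called first, only, known or untested is meant among the compounds shown, and "the series" means these compounds.

Compound 1 `O=c1[nH]cc(S(=O)(=O)Nc2ccccc2-c2cn(-c3ccccc3Cl)nn2)c(=O)[nH]1`: 3170 nM
Compound 2 `O=c1[nH]cc(S(=O)(=O)Nc2ccc(-c3cn(-c4ccccc4)nn3)cc2)c(=O)[nH]1`: 18000 nM
Compound 3 `Cc1ccccc1-n1cc(-c2ccc(NS(=O)(=O)c3c[nH]c(=O)[nH]c3=O)cc2)nn1`: 7310 nM

In a functional assay on OVCAR-3 cells (Homo sapiens) for antiproliferative activity, read by MTT assay, with a stated time of 24 h (on this read-out lower numbers stand for stronger inhibition and higher numbers for weaker inhibition), compound 3 stands second highest of the three numbers: compound 1 gives a lower number, while compound 2 gives a higher one. Going by the values given here, the only single-point step measured so far is a 2.5-fold lower number from compound 2 to compound 3 (0.39 log units; beyond the scatter), which adds a methyl to the ring. Compound 4 `Cc1cccc(-n2cc(-c3ccc(NS(=O)(=O)c4c[nH]c(=O)[nH]c4=O)cc3)nn2)c1` keeps that methyl but moves it: 3-methylphenyl in place of 2-methylphenyl on an aromatic nitrogen. Among the compounds with values here, no measured pair shows what such a shift of position does, so the change from compound 3 is expected to stay within the usual scatter. Compound 4 is therefore estimated at 7000 nM, with a range from 2500 nM to 20000 nM, meaning an expected step of a 1.0-fold lower number from compound 3 to compound 4 (0.02 log units; within the scatter).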

Compound 4, half-maximal inhibitory concentration: 7490 nM
Beside the measured number, compound 4's estimate is 1.1-fold (0.03 log units) below it, and the stated range covers the measured number.
By their numbers in this assay, from the lowest: compound 1; then compounds 3 and 4 (each within the scatter of the next); then compound 2.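

In this assay, moving the methyl from 2-methylphenyl to 3-methylphenyl on the aromatic nitrogen gives a 1.0-fold higher number from compound 3 to compound 4 (0.01 log units; within the scatter), so the two placings cannot be told apart here. Adding a methyl to the phenyl still helps in the new placing, with a 2.4-fold lower number from compound 2 to compound 4 (0.38 log units; beyond the scatter), just as a 2.5-fold lower number from compound 2 to compound 3 (0.39 log units; beyond the scatter) did for 2-methylphenyl. Nothing in the available evidence explains why these numbers behave this way.

Still open, from the compounds shown here alone, is whether the effect belongs to methyl alone. A methoxy group, an amine or a carboxylic acid on this phenyl could move the number differently.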